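The compounds below may be only part of what the source reports. "The series", "measured", "known", "first", "only" and "open" are said of these compounds alone.

Values so far in a functional assay on L1210 cells (Mus musculus) for inhibition; on this read-out higher numbers stand for weaker inhibition and lower numbers for stronger inhibition:
- Compound 1 `C=Cc1cc(=O)[nH]c(=O)n1C1O[C@H](CO)[C@@H](O)[C@H]1O` gives 12000 nM
- Compound 2 `C/C=C/c1cc(=O)[nH]c(=O)n1C1O[C@H](CO)[C@@H](O)[C@H]1O` gives > 35000 nM, which is a limit of the assay and not a number
- Compound 3 `C=Cc1nc(O)nc(O)c1Cl` gives 4500 nM

Compound 3, at 4500 nM, holds the lower of the two actual numbers, and compound 1 sits higher at 12000 nM. Compound 4 `C=Cc1nc(O)nc(O)c1I` is compound 3 with iodo in place of chloro on an aromatic carbon. Within the data shown here, the only measured step, an at least 2.9-fold higher number from compound 1 to compound 2 (0.46 log units; beyond the scatter), puts prop-1-en-1-yl in place of vinyl, a different change, so it offers no direct guide. Among the measured compounds shown here, no measured step involves chloro or iodo. Only a small change is therefore expected in this assay, with no firm direction and probably within the scatter: an estimated 1.1-fold higher number from compound 3 to compound 4 (0.05 log units; within the scatter). Compound 4 is expected at 5000 nM, with an estimated range of 1500 nM to 16000 nM.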

Compound 4, half-maximal inhibitory concentration: 2000 nM
Compound 4: middle estimate off by 2.5-fold (0.40 log units), on the high side, within the range that was stated.
By their numbers in this assay, from the lowest: compound 4; then compound 3; then compound 1. At a limit, above all of these: compound 2.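

In this assay, exchanging chloro for iodo on the aromatic carbon gives a 2.3-fold lower number from compound 3 to compound 4 (0.35 log units; beyond the scatter). Among these compounds, the only earlier step changed the vinyl group, so this is the first sign that the read-out responds to the group at this position, even when one heavy atom simply replaces another. No measurement shown explains this difference.

Two groups at this position give a single step, not a trend. As far as these compounds go, how bromo, fluoro or an amine would compare at this position remains open.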